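The source may report more compounds than this note shows. Statements on the series, on what has been measured and on what is new or still open speak of the compounds shown alone.

In a functional assay on the whole organism for positive allosteric modulation, with Mus musculus as the target (on this read-out lower numbers stand for an effect already at smaller amounts and higher numbers for an effect only at larger amounts of compound), compound 3 `CCC(=O)N(c1cccc(C)c1)C1CCCCC1N(C)C` gives > 50 mg/kg, which is a limit of the assay and not a number. Compound 4 `CCC(=O)N(c1ccc(C)cc1)C1CCCCC1N(C)C` has 4-methylphenyl in place of 3-methylphenyl on an amide-type nitrogen.

Among the measured compounds shown here, two measured steps bear on this change. Compound 1 `CCC(=O)N(c1ccc(Cl)cc1)C1CCCCC1N(C)C`, which carries 4-chlorophenyl on that nitrogen, gives 14 mg/kg. Compound 2 `CCC(=O)N(c1ccc(OC)cc1)C1CCCCC1N(C)C` gives > 50 mg/kg, which is also a limit. Methoxy in place of chloro on an aromatic carbon produced an at least 3.5-fold higher number from compound 1 to compound 2 (0.55 log units; beyond the scatter). Similarly, 3-methylphenyl in place of 4-chlorophenyl produced an at least 3.5-fold higher number from compound 1 to compound 3 (0.55 log units; beyond the scatter). From the compounds shown here alone, both steps end at the limit of > 50 mg/kg in this assay, at which 2 of the 3 values shown sit, so their full size is unknown.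

Compound 4 resembles compound 1 in the naming of its group, 4-methylphenyl against 4-chlorophenyl, but compound 2 goes against any simple rule. A modest move toward a lower number in this assay is expected, although compound 4 may also remain at the limit. The expected change is an at least 1.4-fold lower number from compound 3 to compound 4 (0.15 log units; that floor lies within the scatter). For compound 4, the estimated value is 35 mg/kg, with an expected range from 12 mg/kg to 100 mg/kg.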

Compound 4, dose for half-maximal effect: > 50 mg/kg
Compound 4: no number, only a limit; the forecaster's own chance of this, stated with the estimate: 40%; middle value at least 1.4-fold (0.15 log units) from the limit.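

Swapping 3-methylphenyl for 4-methylphenyl on the amide-type nitrogen does not recover the effect of compound 1 in this assay, and the outcome is an at least 3.5-fold higher number from compound 1 to compound 4 (0.55 log units; beyond the scatter). Among the compounds shown, the 4-chlorophenyl group of compound 1 is therefore the only one that gives a measured value, while methyl at either named arrangement, and methoxy in compound 2, do not. The steps among compound 2, compound 3 and compound 4 cannot be read because all three sit at the same limit: the limit of > 50 mg/kg in this assay, at which 3 of the 4 values shown sit.

From the compounds shown here alone, how far these three compounds actually lie from one another remains open, as does their order. Going by these compounds, it is also open whether chloro is uniquely suited to this place, or whether fluoro, bromo or trifluoromethyl on the aromatic carbon could give a measured value too.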